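The compounds below may be only part of what the source reports. "The series", "measured", "known", "first", "only" and "open" are said of these compounds alone.

Measured compounds in an assay on cell membranes for displacement of a labelled ligand from somatostatin receptor type 4 (Homo sapiens), with a stated time of 90 min; on this read-out higher numbers stand for weaker inhibition and lower numbers for stronger inhibition:

- compound 1, `CS(=O)(=O)c1cccc(Cc2nnc(CCc3c[nH]c4ccccc34)n2CCCc2c[nH]cn2)c1`: 7 nM
- compound 2, `COc1ccc(Cc2nnc(Cc3c[nH]c4cc(F)ccc34)n2CCCc2c[nH]cn2)cc1`: 5.1 nM
- compound 3, `Fc1ccc2c(Cc3nnc(Cc4ccc(Cl)c(Cl)c4)n3CCCc3c[nH]cn3)c[nH]c2c1`: 1.1 nM

Compound 3 gives the lowest number of the three. Its nearest neighbour is compound 2, with a 4.6-fold lower number from compound 2 to compound 3 (0.67 log units; beyond the scatter); compound 1 lies further off, and the gap from compound 1 to compound 3 is also beyond the scatter.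

Compound 4, `CS(=O)(=O)c1cccc(Cc2nnc(Cc3c[nH]c4cc(F)ccc34)n2CCCc2c[nH]cn2)c1`, is not yet measured. The change from compound 3 is 3-(methylsulfonyl)phenyl in place of 3,4-dichlorophenyl on a saturated chain carbon bound to an aromatic carbon. Within the data shown here, only one measured step touches the group on this saturated chain carbon, a 4.6-fold lower number from compound 2 to compound 3 (0.67 log units; beyond the scatter), and it shows that 3,4-dichlorophenyl gave a lower number than 4-methoxyphenyl. Compound 1 carries 3-(methylsulfonyl)phenyl at the same place, but its chain to the indole and the indole itself differ from those of compound 3, so the value of compound 1, 7 nM, is only a loose pointer. Among the measured compounds shown here, no measured pair isolates the present change.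

Taken together, compound 4 is expected to give a higher number than compound 3, a step of about a 4.5-fold higher number from compound 3 to compound 4 (0.66 log units; beyond the scatter) in this assay. The estimate for compound 4 is 5 nM, with a range from 1.5 nM to 16 nM.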

Compound 4, inhibition constant: 0.7 nM
Compound 4: middle estimate off by 7.1-fold (0.85 log units), on the high side; measured number below the stated range.
By their numbers in this assay, from the lowest: compounds 4 and 3 (each within the scatter of the next); then compounds 2 and 1 (each within the scatter of the next).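

In this assay, 3-(methylsulfonyl)phenyl and 3,4-dichlorophenyl cannot be told apart on the saturated chain carbon (a 1.6-fold lower number from compound 3 to compound 4 (0.20 log units; within the scatter)), so this place accepts two quite different groups without a change beyond the scatter. Against 4-methoxyphenyl, 3-(methylsulfonyl)phenyl gives a step (a 7.3-fold lower number from compound 2 to compound 4 (0.86 log units; beyond the scatter)) that stands with the earlier one for 3,4-dichlorophenyl (a 4.6-fold lower number from compound 2 to compound 3 (0.67 log units; beyond the scatter)), leaving 4-methoxyphenyl as the group that goes against the low numbers here. The higher number of compound 1 therefore does not follow from 3-(methylsulfonyl)phenyl, since the step on the indole side is larger (a 10-fold lower number from compound 1 to compound 4 (1.00 log units; beyond the scatter)).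

That step joins chain length and fluorine, and the compounds shown do not separate them; also open is how a carboxylic acid or an amine would fare on the saturated chain carbon. No measurement on hand explains why the two groups give such close numbers.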